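Chain extension from compound 2 to compound 3

The compounds below may be only part of what the source reports. "The series", "measured", "known", "first", "only" and "open" are said of these compounds alone.

Measured so far in an ADME assay on HepG2 cells (Homo sapiens) for cytotoxicity, read by MTT assay, with a stated time of 72 h; a higher number here means a weaker inhibitor, a lower number a stronger inhibitor:
- compound 1 `CCCSSC(=S)N(CC)CC` gives 51000 nM (measured)
- compound 2 `CCCCCCSSC(=S)N(CC)CC` gives 51000 nM (measured)

Compound 2 stands level with compound 1 at the digits shown, and these two values are all the series offers so far. The next compound to be read is compound 3 `CCCCCCCCSSC(=S)N(CC)CC`. It differs from compound 2 in one place: ethyl in place of hydrogen on a saturated chain carbon, six bonds along the chain from a sulfur. In words, this is ethyl in place of hydrogen on a saturated chain carbon, six bonds along the chain from a sulfur.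

Within the data shown here, one measured step bears on this change, the extension of the same chain: no change at the digits printed from compound 1 to compound 2 (within the scatter). There, propyl took the place of hydrogen on a saturated chain carbon, three bonds along the chain from a sulfur. Among the measured compounds shown here, with this single step as the only guide, no step beyond the scatter is expected in this assay and no direction can be assigned. For the measured compounds named here, the data hold no measurement of a chain as long as the one in compound 3, so the range is kept wide. The expected step, an estimate only, is a 1.1-fold lower number from compound 2 to compound 3 (0.05 log units; within the scatter) and it may fall either way. The estimate for compound 3 is 45000 nM (20000 nM to 100000 nM) in this assay's read-out.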

Compound 3, half-maximal inhibitory concentration: 50000 nM
Compound 3: middle estimate off by 1.1-fold (0.05 log units), on the low side, and the stated range covers the measured number.
By their numbers in this assay, from the lowest: compounds 3, 1 and 2 (each within the scatter of the next).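

In this assay, ethyl in place of hydrogen on a saturated chain carbon, six bonds along the chain from a sulfur, gives a 1.0-fold lower number from compound 2 to compound 3 (0.01 log units; within the scatter) and so extends the earlier reading: the propyl step gave no change at the digits printed from compound 1 to compound 2 (within the scatter) at the place three bonds along the chain, and the place six bonds along now reads the same way. Read across the whole series, pentyl in place of hydrogen at that first place gives a 1.0-fold lower number from compound 1 to compound 3 (0.01 log units; within the scatter) and none of the three compounds goes against this, so chain length across this span carries no resolved effect on the read-out in this assay. The data at hand offer nothing that would account for this level reading.

The compounds shown leave open whether a longer chain than the one in compound 3 stays level, and whether a branched chain, or a chain ending in an amine or a carboxylic acid, stays level too. All three compounds also share the same core with its two ethyl groups, so these values say nothing about any change to that part of the structure, such as a cyclohexyl group in place of an ethyl group.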